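Azido in Place of Hydroxyethylamino on the Shared Core

The compounds below may be only part of what the source reports. "The series", "measured", "known", "first", "only" and "open" are said of these compounds alone.

Compound 2 `OCCNc1nccc2c1ncn2C1O[C@H](CO)[C@@H](O)[C@H]1O` carries a (2-hydroxyethyl)amino group on the shared core; in a functional assay (Homo sapiens) for inhibition of Nucleic Acid, tested at 100 uM (on this read-out lower numbers stand for less inhibition and higher numbers for more inhibition at the one concentration tested (going by the name of the read-out)), compound 2 gives 0%. Its nearest neighbour, compound 1 `CN(C)c1nccc2c1ncn2C1O[C@H](CO)[C@@H](O)[C@H]1O`, bears dimethylamino on the same aromatic carbon, and in this assay compound 1 gives 0%. Going by the values given here, the single measured step, no change at the digits printed from compound 1 to compound 2 (within the scatter), therefore shows that exchanging one amino substituent for another at this carbon left the read-out where it was, within the scatter. Compound 3 `[N-]=[N+]=Nc1nccc2c1ncn2C1O[C@H](CO)[C@@H](O)[C@H]1O` has not yet been measured; it differs from compound 2 in one place: azido in place of (2-hydroxyethyl)amino on an aromatic carbon. Among the compounds with values here, no measured step involves an azido group, so the only guidance is that one flat step at the same carbon, which gives no hint of any movement away from the bottom of the scale. On that basis the estimated step of a number 2 percentage points higher from compound 2 to compound 3 (within the scatter) is expected to remain within the scatter. Compound 3 is therefore estimated to give 2% in this assay, with a range from -8% to 15%.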

Compound 3, a percentage reported as inhibition, at one concentration (the size of the read-out at that concentration, not a potency): 4%
Compound 3: middle estimate off by 2 percentage points, on the low side; low and high end bracket the measured number.
By their numbers in this assay, from the lowest: compounds 1, 2 and 3 (each within the scatter of the next).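

The earlier pair showed only one amino substituent exchanged for another, whereas azido brings in a group with no carbon and 0 hydrogen-bond donors, in place of a (2-hydroxyethyl)amino group with 2 hydrogen-bond donors. In this assay this exchange gives a number 4 percentage points higher from compound 2 to compound 3 (within the scatter) and the exchange of dimethylamino for azido gives a number 4 percentage points higher from compound 1 to compound 3 (within the scatter) on the same aromatic carbon next to the ring nitrogen, so all three substituents at this position lie within the scatter of one another and none of these changes separates from the others at the one concentration tested. Nothing among the data given accounts for this flat result.

The compounds shown leave open whether any substituent at this carbon can lift the read-out clearly away from the bottom of the scale, since three groups that all sit so low give no trend to follow. A primary amine, a chloro group, a carboxylic acid or a longer alkylamino chain at this carbon would test that question, and whether changes elsewhere on the shared core matter more also remains unanswered.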